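Trifluoromethyl position on the shared core

The compounds below may be only part of what the source reports. "The series", "measured", "known", "first", "only" and "open" are said of these compounds alone.

Among the compounds with values here, compound 2 `Oc1ccc(-c2cc(-c3ccccc3C(F)(F)F)cc(-c3cccc(O)c3)n2)cc1` is the only compound in this set with a number in a functional assay on HCT-15 cells (Homo sapiens) for inhibition (a higher number here means a weaker inhibitor, a lower number a stronger inhibitor), where compound 2 gives 5740 nM. Compound 1 `Oc1ccc(-c2cc(-c3cccc(C(F)(F)F)c3)cc(-c3ccccc3O)n2)cc1` reaches only a limit of the assay in this assay, > 50000 nM, and the limit of > 50000 nM in this assay, at which 1 of the 2 values shown sits, is all that is known of it. Within the data shown here, compound 1 and compound 2 differ at more than one position, so no single step between them can be read off.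

Compound 3 `Oc1ccc(-c2cc(-c3cccc(C(F)(F)F)c3)cc(-c3cccc(O)c3)n2)cc1` has not been measured. It differs from compound 2 by 3-(trifluoromethyl)phenyl in place of 2-(trifluoromethyl)phenyl on an aromatic carbon. Compound 1 carries the same 3-(trifluoromethyl)phenyl group but a different hydroxyphenyl group, so it does not settle the question. The step from compound 2 to compound 3 is expected to be modest and toward weaker inhibition, a 1.6-fold higher number from compound 2 to compound 3 (0.20 log units; within the scatter), with a real chance that only a limit is reported. For compound 3 the estimate in this assay is 9000 nM, between 2500 nM and 40000 nM.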

Compound 3, half-maximal inhibitory concentration: 9540 nM
The estimate for compound 3 lay 1.1-fold (0.03 log units) below the measured number; the range from low to high includes it.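

Moving the trifluoromethyl group gives a 1.7-fold higher number from compound 2 to compound 3 (0.22 log units; within the scatter), so in this assay the 2-(trifluoromethyl)phenyl and 3-(trifluoromethyl)phenyl groups cannot be told apart on this core when it also carries the 3-hydroxyphenyl and 4-hydroxyphenyl groups. The hydroxyphenyl change can now be read on its own, and 3-hydroxyphenyl in place of 2-hydroxyphenyl gives an at least 5.2-fold lower number from compound 1 to compound 3 (0.71 log units; beyond the scatter), the only step shown that lies beyond the scatter. For compound 1 the value is a limit of the assay and not a number, so this step gives only a bound: the limit of > 50000 nM in this assay, at which 1 of the 3 values shown sits.

From the compounds shown here alone, the true size of that step remains unknown. Also open, going by these compounds, is whether the same flat reading at the trifluoromethyl position would hold for a nitrile, an amine or a carboxylic acid on that phenyl ring.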